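The compounds below may be only part of what the source reports. "The series", "measured", "known", "first", "only" and "open" are said of these compounds alone.

Measured compounds:
Compound 1, `C=C(C)[C@H]1CC=C(C)[C@H]2[C@@H]1[C@H](c1ccccc1Br)O[C@@H]2C(=O)OCC`, in a functional assay on KB3 cells (Homo sapiens) for antiproliferative activity, read by MTT assay, with a stated time of 96 h (on this read-out higher numbers stand for weaker inhibition and lower numbers for stronger inhibition), gives > 100000 nM, a limit of the assay and not a number.
Compound 2, `C=C(C)[C@H]1CC(=O)C(C)=C2[C@@H](C(=O)OCC)O[C@@H](c3cccc(Br)c3)[C@@H]21`, gives 30000 nM.

Going by the values given here, compound 2 thus holds the only numerical value in this assay; the other entry sits at the limit of > 100000 nM in this assay, at which 1 of the 2 values shown sits. Compound 3, `C=C(C)[C@H]1CC(=O)C(C)=C2[C@@H](C(=O)OCC)O[C@@H](c3cccc(Cl)c3Cl)[C@@H]21`, differs from compound 2 by 2,3-dichlorophenyl in place of 3-bromophenyl on a saturated ring carbon. Among the compounds with values here, no measured step of this kind exists among the two compounds, so no direction can be read from them. Compound 3 is expected at 30000 nM (range 8000 nM to 100000 nM). This expectation means a step of no change at the digits printed from compound 2 to compound 3 (within the scatter), not beyond the scatter.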

Compound 3, half-maximal inhibitory concentration: 5000 nM
Beside the measured number, compound 3's estimate is 6.0-fold (0.78 log units) above it, outside the stated range (below it).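

In this assay the aryl group on the saturated ring carbon next to the ring oxygen is shown to affect the read-out: 2,3-dichlorophenyl in place of 3-bromophenyl gives a 6.0-fold lower number from compound 2 to compound 3 (0.78 log units; beyond the scatter) as the first step read at this position. The step lies beyond the scatter, so this position tolerates a change of aryl group with a measurable gain. Nothing at hand bears on why the number moves.

Going by these compounds, whether the gain follows the second halogen or the loss of bromine remains open, and 3-chlorophenyl would separate the two. Also open, on these data alone, is how this position responds to an aryl group carrying an amine or a carboxylic acid.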